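The source may report more compounds than this note shows. Statements on the series, on what has been measured and on what is new or still open speak of the compounds shown alone.

Compound 2 `CNC(=O)c1cc(C(N)=O)cn(Cc2ccccc2)c1=O` is the smaller member of the pair measured in a physicochemical assay for solubility (a higher number here means a more soluble compound, a lower number a less soluble compound), where compound 2 gives 71 ug/mL. Compound 1 `CNC(=O)c1cc(C(=O)NCCC2CCOCC2)cn(Cc2ccccc2)c1=O` reaches only a limit of the assay in this assay, at >= 127 ug/mL (the limit of >= 127 ug/mL in this assay, at which 1 of the 2 values shown sits). Among the compounds with values here, the one measured step, an at least 1.7-fold lower number from compound 1 to compound 2 (0.25 log units; that floor lies within the scatter), sets the only reference. Compound 3 `CNC(=O)c1cc(C(=O)NCCC(C)C)cn(Cc2ccccc2)c1=O` carries the change (isopentyl in place of hydrogen on an amide-type nitrogen), a branched chain rather than the ring-bearing chain of compound 1, so the reference transfers loosely. In this assay compound 3 is expected to shift by a 1.4-fold lower number from compound 2 to compound 3 (0.15 log units; within the scatter), a step not clearly beyond the scatter. The estimate for compound 3 is 50 ug/mL, within 15 ug/mL to 150 ug/mL.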

Compound 3, solubility: 10 ug/mL
The estimate for compound 3 lay 5.0-fold (0.70 log units) above the measured number; measured number outside the range, below it.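

In this assay, isopentyl on the amide-type nitrogen gives a 7.1-fold lower number from compound 2 to compound 3 (0.85 log units; beyond the scatter), a change at this position that the earlier pair did not show beyond the scatter. Isopropyl in place of oxan-4-yl at the chain end gives an at least 12-fold lower number from compound 1 to compound 3 (1.10 log units; beyond the scatter), so the read-out here depends on the end of the chain and not only on the presence of a substituent. That step is a floor, with compound 1 standing at a limit of the assay: the limit of >= 127 ug/mL in this assay, at which 1 of the 3 values shown sits.

Still open, as far as these compounds go, is whether a shorter chain such as ethyl, or a chain ending in an amine or a carboxylic acid, would keep the number near that of compound 2.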